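The source may hold more compounds than are shown below. What is called first, only, known or untested is meant among the compounds shown, and "the series" means these compounds.

Measured compounds:
compound 1 `CS(=O)(=O)c1cc(N)c2ncccc2c1[N+](=O)[O-]` — > 10000 nM
compound 2 `Nc1ccc([S+]([O-])c2cc(N)c3ncccc3c2[N+](=O)[O-])cc1` — 1250 nM

In an assay for binding affinity to Neuropeptide Y receptor type 1 (Homo sapiens), read by radioligand binding (on this read-out higher numbers stand for weaker inhibition and lower numbers for stronger inhibition), compound 1 gives only a limit, > 10000 nM, so no number is known for it; it stands at the limit of > 10000 nM in this assay, at which 1 of the 2 values shown sits. Compound 2 carries an aminophenyl sulfoxide on the shared core and in this assay gives 1250 nM, a real number. Within the data shown here, no step between measured compounds that differ in a single place is available, so the size of any change has to be guessed.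

Compound 3 `Nc1cc(S(=O)(=O)c2ccccc2Cl)c([N+](=O)[O-])c2cccnc12` is not yet measured. It differs from compound 1 by 2-chlorophenyl in place of methyl on a sulfonyl sulfur. The aryl group on the sulfur is the feature that compound 2 also has, and compound 2 reaches 1250 nM, so a gain in affinity beyond the scatter is expected for compound 3, though the guess is uncertain. For compound 3 the expected step is an at least 3.3-fold lower number from compound 1 to compound 3 (0.52 log units; beyond the scatter). Compound 3 is estimated at 3000 nM, between 700 nM and 15000 nM.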

Compound 3, inhibition constant: 93 nM
The estimate for compound 3 lay 32-fold (1.51 log units) above the measured number; the measured number lies below the stated range.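

In this assay, 2-chlorophenyl in place of methyl on a sulfonyl sulfur gives an at least 100-fold lower number from compound 1 to compound 3 (2.03 log units; beyond the scatter). Among these compounds, this is the first step that can be read across a single change, and it shows that an aromatic ring is accepted at this place and that this one change brings a large gain. Compound 1 gives > 10000 nM, which is a limit of the assay and not a number, so the step has a known floor but no known full size: the limit of > 10000 nM in this assay, at which 1 of the 3 values shown sits.

Going by these compounds, whether the gain belongs to the ring or to the chlorine stays open, as does how a plain phenyl, a 2-methoxyphenyl or a cyclohexyl on the same sulfonyl sulfur would read. Compound 2 differs from compound 3 in more than one place, so the pair gives no clean comparison of sulfoxide and sulfonyl.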